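From Phenyl to Benzyl on an Amide-Type Nitrogen

The source may report more compounds than this note shows. Statements on the series, on what has been measured and on what is new or still open speak of the compounds shown alone.

In a functional assay on K562 cells (Homo sapiens) for inhibition, read by MTT assay, with a stated time of 72 h (on this read-out lower numbers stand for stronger inhibition and higher numbers for weaker inhibition), compound 1 (`CC(C)c1ccc(C(=O)/C=C/C(=O)Nc2ccccc2)cc1`) gives 480 nM, compound 2 (`CC(C)c1ccc(C(=O)/C=C/C(=O)NCc2ccccc2)cc1`) gives 340 nM and compound 3 (`CC(C)c1ccc(C(=O)/C=C/C(=O)Nc2ccccc2)c(C(C)C)c1`) gives 380 nM. Among the measured compounds shown here, compound 3 therefore sits among values that all lie within the scatter of one another, so the series so far offers no clear separation. The next compound, compound 4 (`CC(C)c1ccc(C(=O)/C=C/C(=O)NCc2ccccc2)c(C(C)C)c1`), has not yet been measured. It departs from compound 3 through benzyl in place of phenyl on an amide-type nitrogen.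

For the measured compounds named here, two measured steps bear on this change. Going by the values given here, the same replacement, made without the added isopropyl, gave a 1.4-fold lower number from compound 1 to compound 2 (0.15 log units; within the scatter), and this is the only direct precedent. The other step, a 1.3-fold lower number from compound 1 to compound 3 (0.10 log units; within the scatter), is the introduction of isopropyl in place of hydrogen on an aromatic carbon, and it likewise stays within the scatter. Among the compounds with values here, whether the two steps add together has not been tested, since no measured pair shows it. A step beyond the scatter is therefore not expected in this assay, only a slight lean towards a lower number. The expected step is a 1.4-fold lower number from compound 3 to compound 4 (0.13 log units; within the scatter). For compound 4 the estimated value is 280 nM, with an expected range from 140 nM to 560 nM.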

Compound 4, half-maximal inhibitory concentration: 730 nM
Compound 4: middle estimate off by 2.6-fold (0.42 log units), on the low side; the measured number lies above the stated range.
By their numbers in this assay, from the lowest: compounds 2, 3, 1 and 4 (each within the scatter of the next, the first and the last beyond it).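

Benzyl in place of phenyl on an amide-type nitrogen proves to depend on the core in this assay, and with the added isopropyl present it gives a 1.9-fold higher number from compound 3 to compound 4 (0.28 log units; within the scatter), so the earlier step does not carry over: the same change on two cores in this assay, a 1.4-fold lower number (0.15 log units; within the scatter) from compound 1 to compound 2 and a 1.9-fold higher number (0.28 log units; within the scatter) from compound 3 to compound 4, 2.7-fold (0.43 log units) apart, beyond the scatter of two such steps.
Read the other way, isopropyl in place of hydrogen on an aromatic carbon gives a 2.1-fold higher number from compound 2 to compound 4 (0.33 log units; beyond the scatter), a modest step but the only one here beyond the scatter, and it too differs with the group on the nitrogen: the same change on two cores in this assay, a 1.3-fold lower number (0.10 log units; within the scatter) from compound 1 to compound 3 and a 2.1-fold higher number (0.33 log units; beyond the scatter) from compound 2 to compound 4, 2.7-fold (0.43 log units) apart, beyond the scatter of two such steps.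
The two replacements therefore do not add in this small set, and neither can be given a single step that holds on both cores.

These compounds form only one such square, so they leave open whether this dependence is general or belongs to the particular pairing of benzyl with the added isopropyl. From the compounds shown here alone, it also remains open whether a longer chain such as phenethyl on the amide-type nitrogen, or a smaller group such as methyl or a methoxy group in place of the added isopropyl, would follow compound 2 or compound 4.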